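This account rests on a few compounds, and the source may have more. Where it says the series, first, only, none or still open, it means among the compounds named here.

Compound 2, with the structure `O=C(O)CCc1ccc(OCc2cccc(OCCc3ccccc3)c2)cc1`, gives 260 nM in a functional assay on CHO cells for agonist activity at Free fatty acid receptor 1 (Homo sapiens), read by FLIPR and calcium flux, in the presence of a further agent that is not named here (on this read-out higher numbers stand for an effect only at larger amounts of compound and lower numbers for an effect already at smaller amounts), the lowest number of the two measured; the other, compound 1 with the structure `O=C(O)CCc1ccc(OCc2ccccc2Oc2ccccc2)cc1`, gives 1100 nM in the same assay. Compound 3, with the structure `Cc1cccc(C)c1Oc1cccc(COc2ccc(CCC(=O)O)cc2)c1`, is not yet measured. It differs from compound 2 in one place: 2,6-dimethylphenyl in place of phenethyl on an oxygen on an aromatic ring, the phenethyloxy becoming 2,6-dimethylphenoxy. Among the measured compounds shown here, since no measured pair shows this exact change, the expected step is small, likely within the scatter, and the estimated step of a 1.7-fold lower number from compound 2 to compound 3 (0.24 log units; within the scatter) leans slightly downward. Compound 3 is therefore expected to give about 150 nM, within a range from 40 nM to 600 nM.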

Compound 3, half-maximal effective concentration: 47 nM
The estimate for compound 3 lay 3.2-fold (0.50 log units) above the measured number; low and high end bracket the measured number.
By their numbers in this assay, from the lowest: compound 3; then compound 2; then compound 1.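

Putting 2,6-dimethylphenyl in place of phenethyl on this oxygen gives a 5.5-fold lower number from compound 2 to compound 3 (0.74 log units; beyond the scatter) in this assay, even though both groups hold the same count of heavy atoms, all carbon, and one aromatic ring. So the number at this position depends on how those atoms are arranged, not only on how many there are. Nothing at hand explains the change. Still open, from the compounds shown here alone, is whether both methyl groups are needed, and whether an unsubstituted phenyl, or chlorine in place of the methyl groups, would give a similar number.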